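The source may hold more compounds than are shown below. What is called first, only, known or untested is meant among the compounds shown, and "the series" means these compounds.

Measured in an ADME assay on WI-38 cells (Homo sapiens) for antiproliferative activity, read by sulforhodamine B assay, with a stated time of 72 h; on this read-out lower numbers stand for stronger inhibition and higher numbers for weaker inhibition:
Compound 1 `C=CCOC(=O)C1=C2C(=NC1=O)c1cccc3cccc2c13`: 20600 nM
Compound 2 `C=CCOC(=O)C1=C2C(=NC1=O)c1cccc3c(SCCC)ccc2c13`: 33200 nM
Compound 3 `C=CCSc1ccc2c3c(cccc13)C1=NC(=O)C(C(=O)OCC(=O)SCCC)=C12`: > 100000 nM

For compound 3, the reading of > 100000 nM is a limit of the assay and not a number. Compound 4 `C=CCOC(=O)C1=C2C(=NC1=O)c1cccc3c(SCC=C)ccc2c13` differs from compound 3 by vinyl in place of (propylsulfanyl)carbonyl on a saturated chain carbon bound to an oxygen next to a carbonyl group. In other words, (((propylsulfanyl)carbonyl)methoxy)carbonyl gives way to allyloxycarbonyl, the group also carried by compounds 1 and 2. For the measured compounds named here, no measured step covers this change directly. Going by the values given here, the only measured step, a 1.6-fold higher number from compound 1 to compound 2 (0.21 log units; within the scatter), places propylsulfanyl in place of hydrogen on an aromatic carbon. A lower number is expected, near compound 2 at 33200 nM. The estimated change is an at least 3.3-fold lower number from compound 3 to compound 4 (0.52 log units; beyond the scatter). For compound 4, the estimate is 30000 nM, with an expected range from 12000 nM to 75000 nM.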

Compound 4, half-maximal inhibitory concentration: 19700 nM
Compound 4: middle estimate off by 1.5-fold (0.18 log units), on the high side; the measured number falls inside the stated range.
By their numbers in this assay, from the lowest: compounds 4, 1 and 2 (each within the scatter of the next). At a limit, above all of these: compound 3.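

In this assay, for the compounds shown here, the group on the carbonyl is the first place where a change reads beyond the scatter: allyloxycarbonyl in place of (((propylsulfanyl)carbonyl)methoxy)carbonyl gives an at least 5.0-fold lower number from compound 3 to compound 4 (0.70 log units; beyond the scatter) and separates the two compounds. The sulfur chain does not do this: a 1.7-fold lower number from compound 2 to compound 4 (0.23 log units; within the scatter) and a 1.0-fold lower number from compound 1 to compound 4 (0.02 log units; within the scatter) leave vinyl in place of ethyl and allylsulfanyl in place of hydrogen without a readable effect. The reading for compound 3 is a limit of the assay and not a number: the limit of > 100000 nM in this assay, at which 1 of the 4 values shown sits.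

Still open, as far as these compounds go, is whether a carboxylic acid or a plain longer chain ester at this place would read like compound 4 or like compound 3. Also open, from the compounds shown here alone, is how an amine on the sulfur chain would read.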